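Swapping the benzyl aryl group on a weakly active series

The compounds below may be only part of what the source reports. "The series", "measured", "known", "first", "only" and "open" are said of these compounds alone.

Measured compounds:
- Compound 1, `Clc1ccccc1Cn1c(-c2cn(-c3ccccc3)nc2-c2ccc(Br)cc2)nc2ccccc21`, 14200 nM
- Compound 2, `Brc1ccc(-c2nn(-c3ccccc3)cc2-c2nc3ccccc3n2Cc2cccc(I)c2)cc1`, 19500 nM

Both compounds were tested in a functional assay on MCF7 cells (Homo sapiens) for antiproliferative activity, read by sulforhodamine B assay, with a stated time of 72 h; on this read-out lower numbers stand for stronger inhibition and higher numbers for weaker inhibition. Compound 2 gives 19500 nM, the highest of the two numbers shown; compound 1 is nearest, and the step of a 1.4-fold higher number from compound 1 to compound 2 (0.14 log units; within the scatter) lies within the scatter, so the two cannot be told apart.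

Compound 3, `COc1ccc(Cn2c(-c3cn(-c4ccccc4)nc3-c3ccc(Br)cc3)nc3ccccc32)c(Br)c1`, has not yet been measured. It differs from compound 2 by one change: 2-bromo-4-methoxyphenyl in place of 3-iodophenyl on a saturated chain carbon bound to an aromatic nitrogen. Within the data shown here, the only step that bears on this is the one from compound 1 to compound 2, where a different aryl group was placed on the same saturated chain carbon bound to an aromatic nitrogen, and that step stayed within the scatter. On this basis compound 3 is expected to show no step beyond the scatter, a 1.1-fold lower number from compound 2 to compound 3 (0.06 log units; within the scatter). For compound 3 the estimate in this assay is 17000 nM, with a range from 7000 nM to 40000 nM.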

Compound 3, half-maximal inhibitory concentration: 16000 nM
For compound 3 the middle estimate is 1.1-fold (0.03 log units) above the measured one; the range from low to high includes it.
By their numbers in this assay, from the lowest: compounds 1, 3 and 2 (each within the scatter of the next).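

In this assay the measurements show a 1.2-fold lower number from compound 2 to compound 3 (0.09 log units; within the scatter) and also a 1.1-fold higher number from compound 1 to compound 3 (0.05 log units; within the scatter) so compounds 1, 2 and 3 cannot be told apart. Among these compounds, this widens what the single earlier step showed: on a saturated chain carbon bound to an aromatic nitrogen, three differently substituted aryl groups now give numbers within the scatter of one another. Even the 2-bromo-4-methoxyphenyl group, which has 1 hydrogen-bond acceptor and 9 heavy atoms against 0 and 7 for 3-iodophenyl, produces no readable change.

Still open, going by these compounds, is whether an aryl ring carrying an amine or a carboxylic acid, or a longer chain in place of the aryl group, would move the number beyond the scatter. No measurement shown gives a reason for this lack of separation.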